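Replacing the Piperazine Methyl with a Pyridinyl Ring

The source may hold more compounds than are shown below. What is called first, only, known or untested is meant among the compounds shown, and "the series" means these compounds.

Three measured compounds share one core and differ only in the amine at the end of a three-carbon chain that starts from an oxygen on the aromatic ring. In a functional assay on DU-145 cells (Homo sapiens) for antiproliferative activity, read by MTT assay, with a stated time of 72 h (on this read-out higher numbers stand for weaker inhibition and lower numbers for stronger inhibition), compound 1 `COc1cc2c(Nc3ccc(C#N)cc3)ncnc2cc1OCCCN(C)Cc1ccccc1` gives only a limit, > 100000 nM, which is the limit of > 100000 nM in this assay, at which 1 of the 3 values shown sits. Compound 2 `COc1cc2c(Nc3ccc(C#N)cc3)ncnc2cc1OCCCN1CCC(N2CCCCC2)CC1` gives 15600 nM in this assay. Compound 3 `COc1cc2c(Nc3ccc(C#N)cc3)ncnc2cc1OCCCN1CCN(C)CC1` gives 46500 nM in this assay, the highest of the two values that are actual numbers. The steps among them were an at least 6.4-fold lower number from compound 1 to compound 2 (0.80 log units; beyond the scatter), an at least 2.1-fold lower number from compound 1 to compound 3 (0.33 log units; beyond the scatter) and a 3.0-fold higher number from compound 2 to compound 3 (0.47 log units; beyond the scatter).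

Compound 4 `COc1cc2c(Nc3ccc(C#N)cc3)ncnc2cc1OCCCN1CCN(c2ccncc2)CC1` differs from compound 3 by pyridin-4-yl in place of methyl on an amine nitrogen in a ring. Within the data shown here, no measured step alters this same nitrogen while keeping the rest of the ring, so any expectation is indirect. The nearest comparison is a 3.0-fold higher number from compound 2 to compound 3 (0.47 log units; beyond the scatter), where the ring carrying a larger group on its far nitrogen gave the lower number. On that basis compound 4 is expected to give a modestly lower number than compound 3, or none beyond the scatter, a step of a 1.9-fold lower number from compound 3 to compound 4 (0.27 log units; within the scatter). The estimate for compound 4 in this assay is 25000 nM, expected to fall between 8000 nM and 90000 nM.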

Compound 4, half-maximal inhibitory concentration: 22900 nM
Compound 4: the middle estimate sits 1.1-fold (0.04 log units) above what was measured; measured number inside the range.
By their numbers in this assay, from the lowest: compounds 2 and 4 (each within the scatter of the next); then compound 3. At a limit, above all of these: compound 1.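

In this assay, the ring amine nitrogen now has a step of its own: pyridin-4-yl in place of methyl, which brings in a six-membered aromatic ring and one hydrogen-bond acceptor, gives a 2.0-fold lower number from compound 3 to compound 4 (0.31 log units; beyond the scatter), so a change at this nitrogen alone, with the rest of the ring kept, moves the number past the usual scatter. Two quite different end groups, 4-(pyridin-4-yl)piperazin-1-yl and 4-(piperidin-1-yl)piperidin-1-yl, are separated only by a 1.5-fold higher number from compound 2 to compound 4 (0.17 log units; within the scatter), so these two cannot be ranked against each other. Starting from the benzyl(methyl)amino end group, the step reads an at least 4.3-fold lower number from compound 1 to compound 4 (0.64 log units; beyond the scatter), and compound 1 is a limit, not a number: the limit of > 100000 nM in this assay, at which 1 of the 4 values shown sits.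

The compounds shown cannot tell whether the aromatic ring, its ring nitrogen or simply a larger group goes with the lower number; a phenyl or a cyclohexyl on the same nitrogen would help to separate these. On these data alone, how 4-(pyridin-4-yl)piperazin-1-yl behaves on a shorter or longer chain than the three-carbon one also stays open.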